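The source may report more compounds than this note shows. Statements on the series, on what has been measured and on what is new or still open speak of the compounds shown alone.

Compound 3, with the structure `COC(C)(C)CCCC(C)C/C=C/C(C)=C/C(=O)OC1CC1`, stands lowest of the three compounds in a physicochemical assay for lipophilicity (a lower number here means a more polar compound, a higher number a more lipophilic compound), where compound 3 gives 5.71. Compound 2, with the structure `CC(/C=C/CC(C)CCCC(C)C)=C\C(=O)OC(C)C`, gives 7.15, and compound 1, with the structure `CCCOC(=O)/C=C(C)/C=C/CC(C)CCCC(C)C`, gives 7.28. Among the measured compounds shown here, the one step measured between near neighbours is a number 0.13 log units lower from compound 1 to compound 2 (within the scatter). Compound 4, with the structure `CCCC(=O)/C=C(C)/C=C/CC(C)CCCC(C)(C)OC`, differs from compound 3 in one place: propyl in place of cyclopropyloxy on a carbonyl carbon. For the measured compounds named here, no measured step covers this change, since the step between compound 1 and compound 2 only swaps alkyl groups on the ester oxygen. With an oxygen lost, a moderate rise in this assay is expected, a number 0.39 log units higher from compound 3 to compound 4 (beyond the scatter), giving compound 4 an estimated 6.1 in a range from 5.6 to 6.6.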

Compound 4, partition coefficient: 5.61
The estimate for compound 4 lay 0.49 log units above the measured number, and the stated range covers the measured number.
By their numbers in this assay, from the lowest: compounds 4 and 3 (each within the scatter of the next); then compounds 2 and 1 (each within the scatter of the next).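

In this assay, the change gives a number 0.10 log units lower from compound 3 to compound 4 (within the scatter) for propyl in place of cyclopropyloxy on a carbonyl carbon. At this position, then, the ring and its oxygen can both go without a shift beyond the scatter, which the earlier swap of alkyl groups on the ester oxygen could not show. Nothing available explains this result.

From the compounds shown here alone, whether an amine or a longer chain on this carbonyl carbon would also stay within the scatter remains open. So does whether the same change behaves alike on the core of compound 1.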